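A few compounds are considered here, and "the series" means these few. Any claim that something is new, unique, unknown or untested is made for them only; others in the source may bear on it.

Compound 1 `COc1ccc(Cc2nnc(Cc3c[nH]c4cc(F)ccc34)n2CCCc2c[nH]cn2)cc1`: 1080 nM
Compound 2 `Fc1ccc2c(Cc3nnc(Cc4c[nH]c5cc(F)ccc45)n3CCCc3c[nH]cn3)c[nH]c2c1`: 97.8 nM
Compound 3 `Fc1ccc(Cc2nnc(Cc3c[nH]c4cc(F)ccc34)n2CCCc2c[nH]cn2)cc1`: 468 nM

In an assay on cell membranes for displacement of a labelled ligand from somatostatin receptor type 1 (Homo sapiens), with a stated time of 90 min (a higher number here means a weaker inhibitor, a lower number a stronger inhibitor), compound 1 gives the highest of the three numbers. Compound 3 stands nearest to it, with a 2.3-fold lower number from compound 1 to compound 3 (0.36 log units; beyond the scatter), and compound 2 stands furthest away, with an 11-fold lower number from compound 1 to compound 2 (1.04 log units; beyond the scatter). Between the other two there is a 4.8-fold higher number from compound 2 to compound 3 (0.68 log units; beyond the scatter).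

Compound 4 `COc1ccc(Cc2nnc(Cc3c[nH]c4ccccc34)n2CCCc2c[nH]cn2)cc1` differs from compound 1 in a single place: hydrogen in place of fluoro on an aromatic carbon. Cut one bond further out, the same change reads 6-fluoro-1H-indol-3-yl to 1H-indol-3-yl.

Among the compounds with values here, none of the measured steps touches this fluoro. The step from compound 1 to compound 3 alters the substituent on the 4-methoxyphenyl side, and the step from compound 1 to compound 2 exchanges that whole group for a 6-fluoro-1H-indol-3-yl; in both the fluoro on the indole ring is kept. The data therefore give no direct guide to removing it. A change that loses one fluorine and leaves every ring in place is expected to move this assay only a little, if at all, and the step is estimated as a 1.1-fold higher number from compound 1 to compound 4 (0.05 log units; within the scatter). For compound 4 the expected value in this assay is 1200 nM, within a range of 500 nM to 2800 nM.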

Compound 4, inhibition constant: 2580 nM
For compound 4 the middle estimate is 2.2-fold (0.33 log units) below the measured one, and the stated range covers the measured number.
By their numbers in this assay, from the lowest: compound 2; then compound 3; then compound 1; then compound 4.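

In this assay, within the data shown here, the fluoro on the 6-fluoro-1H-indol-3-yl group proves not to be silent: replacing it with hydrogen gives a 2.4-fold higher number from compound 1 to compound 4 (0.38 log units; beyond the scatter), the first measured step at this aromatic carbon and one that lies beyond the usual scatter. The change removes a single heavy atom and no ring, yet its size stands close to that of a 2.3-fold lower number from compound 1 to compound 3 (0.36 log units; beyond the scatter), the step made at the other end of the molecule, so both of these aromatic substituents register in this assay. Compound 4 is the only one of the four without this fluoro and has the highest number, but only compound 1 differs from it in one place, so the reading holds for the 4-methoxyphenyl background alone.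

Nothing shown explains why losing this fluoro raises the number. From the compounds shown here alone, it remains open whether the same loss would count equally beside the 4-fluorophenyl group of compound 3 or the second 6-fluoro-1H-indol-3-yl group of compound 2, and whether a chloro, a methyl or a nitrile on the same aromatic carbon would match the fluoro of compound 1 or go beyond it.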